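The source may report more compounds than this note shows. Statements on the series, on what has been measured and on what is new or still open speak of the compounds shown alone.

Measured so far in a functional assay on WI-38 VA13 cells (Homo sapiens) for cytotoxicity; on this read-out lower numbers stand for an effect already at smaller amounts and higher numbers for an effect only at larger amounts of compound:
Compound 1 `Cc1ccccc1C(=O)Nc1ccc2nc(NC(=O)C3CCCCC3)sc2c1`: 0.085 ug/mL
Compound 2 `O=C(Nc1ccc2nc(NC(=O)C3CCCCC3)sc2c1)c1ccccc1C(F)(F)F`: 0.024 ug/mL
Compound 3 `N#Cc1ccc(C(=O)Nc2ccc3nc(NC(=O)C4CCCCC4)sc3c2)cc1`: 3.3 ug/mL

Compound 3 has the highest number of the three, so it takes the largest amount to show an effect. Compound 4 `O=C(Nc1ccc2nc(NC(=O)C3CCCCC3)sc2c1)c1c(Cl)cccc1Cl` differs from it by one change, 2,6-dichlorophenyl in place of 4-cyanophenyl on a carbonyl carbon. Two large steps bear on this, a 39-fold higher number from compound 1 to compound 3 (1.59 log units; beyond the scatter) and a 140-fold higher number from compound 2 to compound 3 (2.14 log units; beyond the scatter), each bringing in 4-cyanophenyl. The name 2,6-dichlorophenyl shares its leading 2 with 2-methylphenyl and 2-(trifluoromethyl)phenyl, and those two groups differ only by the modest 3.5-fold lower number from compound 1 to compound 2 (0.55 log units; beyond the scatter). Among the measured compounds shown here, no measured compound carries 2,6-dichlorophenyl itself, so the expectation is uncertain. A large drop in this assay is expected, an estimated 41-fold lower number from compound 3 to compound 4 (1.62 log units; beyond the scatter). For compound 4 the estimated value is 0.08 ug/mL, within a range of 0.015 ug/mL to 0.5 ug/mL.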

Compound 4, half-maximal effective concentration: 0.015 ug/mL
Estimate against measurement, compound 4: 5.3-fold (0.73 log units) above, and the stated range covers the measured number.
By their numbers in this assay, from the lowest: compounds 4 and 2 (each within the scatter of the next); then compound 1; then compound 3.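

In this assay 2,6-dichlorophenyl on this carbonyl carbon brings a 220-fold lower number from compound 3 to compound 4 (2.34 log units; beyond the scatter) and so joins 2-methylphenyl and 2-(trifluoromethyl)phenyl at the low end of the numbers, far from 4-cyanophenyl. Replacing those two groups gives a 1.6-fold lower number from compound 2 to compound 4 (0.20 log units; within the scatter) and a 5.7-fold lower number from compound 1 to compound 4 (0.75 log units; beyond the scatter) so compound 4 sits level with compound 2 and lower than compound 1. Nothing measured here explains these differences.

Still open, going by these compounds, is how 2-chlorophenyl, with a single chlorine, or 4-methylphenyl would read at this carbonyl carbon. On these data alone, a phenyl ring carrying an amine or a carboxylic acid is equally open.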